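Cyclopropyl on the amide nitrogen of compound 3

A few compounds are considered here, and "the series" means these few. Any claim that something is new, unique, unknown or untested is made for them only; others in the source may bear on it.

Compound 1 `CC[C@H]1CN(c2ncc(C(N)=O)nc2C(F)(F)F)CCN1C1CCN(C(=O)c2ccc(Cl)nc2N)CC1` gives 8280 ng.h/mL
Compound 2 `CC[C@H]1CN(c2ncc(C(=O)NC3CC3)nc2C(F)(F)F)CCN1C1CCN(C(=O)c2ccc(Cl)nc2N)CC1` gives 2090 ng.h/mL
Compound 3 `CC[C@H]1CN(c2ncc(C(N)=O)nc2C)CCN1C1CCN(C(=O)c2ccc(Cl)nc2N)CC1` gives 14700 ng.h/mL

These three values come from an ADME assay on the whole organism for pharmacokinetics, with Rattus norvegicus as the target, with a stated time of 6 h, at a dose of 10 mg/kg by the oral route (a lower number here means less compound in the circulation, a higher number more compound in the circulation at the dose given), and are all that has been measured so far. Compound 3 at 14700 ng.h/mL cannot be separated from compound 1, as a 1.8-fold higher number from compound 1 to compound 3 (0.25 log units; within the scatter) shows, while compound 2 at 2090 ng.h/mL has the clearly lower number of the pair formed with compound 3.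

Compound 4 `CC[C@H]1CN(c2ncc(C(=O)NC3CC3)nc2C)CCN1C1CCN(C(=O)c2ccc(Cl)nc2N)CC1` is reached from compound 3 by a single structural change (cyclopropyl in place of hydrogen on an amide-type nitrogen), cyclopropyl in place of hydrogen on an amide-type nitrogen. The same change has been measured once, on the trifluoromethyl counterpart, where it gave a 4.0-fold lower number from compound 1 to compound 2 (0.60 log units; beyond the scatter) and so went beyond the scatter. The other measured step, a 1.8-fold higher number from compound 1 to compound 3 (0.25 log units; within the scatter), is the methyl in place of trifluoromethyl swap that separates the two backgrounds, and it stays within the scatter. With one instance only, nothing shows whether the change behaves the same on the methyl compound. A drop of similar size is nevertheless expected, and the estimated step is a 4.0-fold lower number from compound 3 to compound 4 (0.60 log units; beyond the scatter) in this direction. For compound 4 the estimate is 3700 ng.h/mL with an expected range from 1600 ng.h/mL to 8500 ng.h/mL.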

Compound 4, area under the concentration-time curve: 11600 ng.h/mL
For compound 4 the middle estimate is 3.1-fold (0.50 log units) below the measured one; the whole stated range lies below it.
By their numbers in this assay, from the lowest: compound 2; then compounds 1, 4 and 3 (each within the scatter of the next).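

On the methyl core, cyclopropyl in place of hydrogen on an amide-type nitrogen leaves this assay without a separable change, a 1.3-fold lower number from compound 3 to compound 4 (0.10 log units; within the scatter), so the drop seen with trifluoromethyl does not carry over and the size of this step depends on the core: the same change on two cores in this assay, a 4.0-fold lower number (0.60 log units; beyond the scatter) from compound 1 to compound 2 and a 1.3-fold lower number (0.10 log units; within the scatter) from compound 3 to compound 4, 3.1-fold (0.50 log units) apart, beyond the scatter of two such steps Read the other way, methyl in place of trifluoromethyl on an aromatic carbon, which stayed within the scatter while the amide nitrogen carried hydrogen, gives a 5.6-fold higher number from compound 2 to compound 4 (0.74 log units; beyond the scatter) once cyclopropyl sits there, so this swap also depends on its partner: the same change on two cores in this assay, a 1.8-fold higher number (0.25 log units; within the scatter) from compound 1 to compound 3 and a 5.6-fold higher number (0.74 log units; beyond the scatter) from compound 2 to compound 4, 3.1-fold (0.50 log units) apart, beyond the scatter of two such steps Among these four compounds the two changes therefore do not add up, and the clearly low number belongs only to compound 2, the one compound that carries trifluoromethyl and cyclopropyl together.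

The compounds shown leave open whether the methyl core accepts other groups on the amide nitrogen in the same way, such as a methyl, an isopropyl or a cyclobutyl. They also do not tell why the two cores respond differently, or whether a chlorine or an ethyl on the aromatic carbon would behave like methyl or like trifluoromethyl.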